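The source may hold more compounds than are shown below. What is called first, only, known or untested is meant among the compounds shown, and "the series" means these compounds.

Compound 1 `COCCC1=C(N2CC2)C(=O)C(CCOC)=C(N2CC2)C1=O` gives 5.69 in a functional assay on L1210 cells (Mus musculus), with a stated time of 12 days; a lower number here means a less potent compound, a higher number a more potent compound, by a factor of ten per unit of this negative logarithm. Compound 2 `CC1=C(N2CC2)C(=O)C(N2CC2)=C(N2CC2)C1=O` gives 6.77 in this assay. Compound 3 `COCCOC(COC(N)=O)C1=C(N2CC2)C(=O)C(C)=C(N2CC2)C1=O` gives 6.03 in this assay.

Compound 2 stands highest of the three numbers in this assay: compound 3 lies nearest, with a number beyond the scatter lower, and compound 1 lies furthest, also beyond the scatter lower. Compound 4 `CC1=C(N2CC2)C(=O)C(CCCOC(N)=O)=C(N2CC2)C1=O` has not yet been measured. It differs from compound 2 in one place: a group of 7 heavy atoms (4 carbon, 1 nitrogen, 2 oxygen; no ring) in place of a group of 3 heavy atoms (2 carbon, 1 nitrogen; one three-membered non-aromatic ring with 1 hetero atom), on a double-bonded ring carbon. Going by the values given here, no pair of measured compounds differing in a single place is available, so the size of this step cannot be read from any measured pair. What the three values show is that compound 2, which carries the aziridin-1-yl group that leaves here, gives a higher number than compounds 1 and 3. On that basis a loss in this assay is expected for compound 4, a step beyond the scatter, estimated at a number 0.57 log units lower from compound 2 to compound 4 (beyond the scatter). Compound 4 is therefore expected to give about 6.2 in this assay, with a range from 5.6 to 6.8.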

Compound 4, logarithm of the reciprocal of the active concentration, log(1/C): 6.18
Beside the measured number, compound 4's estimate is 0.02 log units above it; low and high end bracket the measured number.
By their numbers in this assay, from the lowest: compound 1; then compounds 3 and 4 (each within the scatter of the next); then compound 2.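

Going by these compounds alone, compound 4 gives the first comparison that changes a single place, on a double-bonded ring carbon next to the ring atom that bears an aziridin-1-yl group. In this assay, replacing the aziridin-1-yl group at this position with the open chain, which has no ring, is a number 0.59 log units lower from compound 2 to compound 4 (beyond the scatter), so the change costs potency but only a modest amount. The data offer no measurement that explains this loss.

This single step cannot separate the effect of removing the aziridin-1-yl group from the effect of the particular chain that enters. On these data alone, it remains open how a methyl group, a shorter or longer chain, an amine or a carboxylic acid at this position would compare in this assay.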